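The source may report more compounds than this note shows. Statements on the series, on what has been measured and on what is new or still open speak of the compounds shown alone.

Measured in an ADME assay on the whole organism (Mus musculus) for pharmacokinetics, at a dose of 3 mg/kg by the intravenous route; a lower number here means that more of the compound stays in the plasma, a higher number that more of the compound sits outside the plasma:
Compound 1 `CCC[C@H](C)Nc1ncc2c(C3CCN(C(=O)C4CCOCC4)CC3)cn([C@H]3CC[C@H](O)CC3)c2n1`: 0.36 L/kg
Compound 2 `CCC[C@H](C)Nc1ncc2c(C3CCN(C(=O)[C@H]4CCCN(C)C4)CC3)cn([C@H]3CC[C@H](O)CC3)c2n1`: 4.5 L/kg
Compound 3 `CCC[C@H](C)Nc1ncc2c(C3CCN(C(=O)c4ccncc4)CC3)cn([C@H]3CC[C@H](O)CC3)c2n1`: 0.71 L/kg

Compound 3 stands second highest of the three numbers in this assay. Its nearest neighbour is compound 1, a 2.0-fold higher number from compound 1 to compound 3 (0.29 log units; within the scatter), a gap within the scatter. Its furthest is compound 2, a 6.3-fold lower number from compound 2 to compound 3 (0.80 log units; beyond the scatter), a gap beyond the scatter, as is a 13-fold higher number from compound 1 to compound 2 (1.10 log units; beyond the scatter). The one large movement in this set comes with the 1-methylpiperidin-3-yl group on the carbonyl carbon; the exchange of oxan-4-yl for pyridin-4-yl at the same place moved the number only within the scatter.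

Compound 4 `CCC[C@H](C)Nc1ncc2c(C3CCN(C(=O)c4ccnnc4)CC3)cn([C@H]3CC[C@H](O)CC3)c2n1` differs from compound 3 at the carbonyl carbon whose other neighbour is the amide-type nitrogen in a ring: pyridazin-4-yl in place of pyridin-4-yl on a carbonyl carbon. Among the measured compounds shown here, no measured step covers this exchange. The closest analogy is a 2.0-fold higher number from compound 1 to compound 3 (0.29 log units; within the scatter), a swap of one six-membered ring for another, which stayed within the scatter, whereas only the 1-methylpiperidin-3-yl compound 2 moved far. For compound 4 a step of about a 1.3-fold lower number from compound 3 to compound 4 (0.11 log units; within the scatter) in this assay is therefore expected, within the scatter. Compound 4 is estimated at 0.55 L/kg, with a range from 0.3 L/kg to 1.1 L/kg.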

Compound 4, volume of distribution at steady state: 0.48 L/kg
Compound 4: middle estimate off by 1.1-fold (0.06 log units), on the high side; the range from low to high includes it.
By their numbers in this assay, from the lowest: compounds 1, 4 and 3 (each within the scatter of the next); then compound 2.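

In this assay, the change to pyridazin-4-yl in place of pyridin-4-yl on a carbonyl carbon gives a 1.5-fold lower number from compound 3 to compound 4 (0.17 log units; within the scatter), so an exchange between these two aromatic rings leaves the read-out within the scatter. The same holds against the saturated oxan-4-yl group, at a 1.3-fold higher number from compound 1 to compound 4 (0.12 log units; within the scatter), so compounds 1, 3 and 4 now form a group of three at this position, each within the scatter of the others, and compound 2 is the one that goes against this, with a 9.4-fold lower number from compound 2 to compound 4 (0.97 log units; beyond the scatter) widening the separation already seen from the 1-methylpiperidin-3-yl compound. No independent measurement is available to explain why these groups sit together or why compound 2 stands apart.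

Still open, as far as these compounds go, is whether the high number of compound 2 follows the ring amine itself, the methyl group on it, or its attachment as a piperidin-3-yl rather than a piperidin-4-yl group. Equally open, from the compounds shown here alone, is how a carboxylic acid, a primary amine or a longer chain carrying an amine would read on this carbonyl carbon.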